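The source may hold more compounds than are shown below. What is called first, only, known or untested is meant among the compounds shown, and "the series" means these compounds.

Series notes. Compound 1 `Cc1ccc2ccc(-c3cc(C#N)cc(C#N)c3)cc2n1` gives 2 nM in a functional assay on CHO cells for inhibition of metabotropic glutamate receptor 5 (Rattus norvegicus), read by FLIPR and calcium flux; on this read-out lower numbers stand for stronger inhibition and higher numbers for weaker inhibition. Compound 2 `Cc1ccc2ccc(-c3cc(C#N)cc(OC(F)(F)F)c3)cc2n1` gives 75 nM in this assay. Compound 3 `Cc1ccc2ccc(-c3cc(O)cc(C#N)c3)cc2n1` gives 360 nM in this assay, the highest of the three numbers, set by a 180-fold higher number from compound 1 to compound 3 (2.26 log units; beyond the scatter) and by a 4.8-fold higher number from compound 2 to compound 3 (0.68 log units; beyond the scatter). Compound 4 `Cc1ccc2ccc(-c3cc(C#N)cc(OCC(C)C)c3)cc2n1` carries isobutyl in place of hydrogen on an oxygen on an aromatic ring. Among the measured compounds shown here, the only measured step touching that oxygen is a 4.8-fold higher number from compound 2 to compound 3 (0.68 log units; beyond the scatter), which read in reverse shows that capping the hydroxy lowered the number; trifluoromethyl is not isobutyl, so the size carries uncertainty. A modest fall in this assay is therefore expected, a 4.5-fold lower number from compound 3 to compound 4 (0.65 log units; beyond the scatter). For compound 4 the expected value in this assay is 80 nM, estimated between 20 nM and 350 nM.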

Compound 4, half-maximal inhibitory concentration: 12000 nM
Beside the measured number, compound 4's estimate is 150-fold (2.18 log units) below it; measured number outside the range, above it.
By their numbers in this assay, from the lowest: compound 1; then compound 2; then compound 3; then compound 4.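

Capping the oxygen on an aromatic ring has no single direction in this assay: trifluoromethyl gave a lower number than hydrogen, whereas isobutyl gives a 33-fold higher number from compound 3 to compound 4 (1.52 log units; beyond the scatter) and a 160-fold higher number from compound 2 to compound 4 (2.20 log units; beyond the scatter). The identity of the capping group therefore sets the direction of the change at this oxygen, and replacing the nitrile with isobutoxy gives a 6000-fold higher number from compound 1 to compound 4 (3.78 log units; beyond the scatter). No measurement offered here accounts for this reversal.

On these data alone, whether methyl or ethyl on the same oxygen falls nearer compound 2 or compound 4 remains open. So does the effect of an amine at this place.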